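Swapping Ethoxy for Isopropyl on a Glucagon Receptor Antagonist

The compounds below may be only part of what the source reports. "The series", "measured", "known", "first", "only" and "open" are said of these compounds alone.

Compound 1, `CCOc1ccc2cc(-c3cc(-c4cc(Cl)cc(Cl)c4)nn3[C@@H](C)c3ccc(C(=O)NCCC(=O)O)cc3)ccc2c1`: 23.6 nM
Compound 2, `CC(c1ccc(C(=O)NCCC(=O)O)cc1)n1nc(-c2cc(Cl)cc(Cl)c2)cc1-c1ccccc1C1CCCCC1`: 362 nM
Compound 3, `COc1cc(Cl)cc(-c2cc(-c3ccc4cc(OC)ccc4c3)n([C@@H](C)c3ccc(C(=O)NCCC(=O)O)cc3)n2)c1`: 67.9 nM

Of the compounds shown here, three built on a shared core have been tested in a functional assay on CHO cells for antagonist activity at Glucagon receptor (Homo sapiens), read by scintillation counting and cAMP accumulation, with a stated time of 30 min; on this read-out lower numbers stand for stronger inhibition and higher numbers for weaker inhibition. Compound 1 gives 23.6 nM, the lowest number of the three and so the strongest inhibition seen here. Compound 3 comes nearest to it, yet its number is higher by a gap that lies beyond the usual scatter of this assay, and compound 2 stands furthest away, weaker by a gap that is clearly beyond the scatter as well.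

The new compound 4, `CC(C)c1ccc2cc(-c3cc(-c4cc(Cl)cc(Cl)c4)nn3[C@@H](C)c3ccc(C(=O)NCCC(=O)O)cc3)ccc2c1`, differs from compound 1 in a single spot: isopropyl in place of ethoxy on an aromatic carbon. The two groups are of the same size, and the only counted loss is the one hydrogen-bond acceptor of the ethoxy; no ring is added or removed and no charge changes. Among the compounds with values here, no pair of measured compounds differing only in this spot is available, so the expectation rests on the small size of the change alone.

Against that background compound 4 is expected to sit close to compound 1, with a step that may be slightly toward weaker inhibition but need not exceed the scatter. The estimate for compound 4 is 40 nM in this assay, expected to fall between 12 nM and 130 nM, which amounts to an expected step of a 1.7-fold higher number from compound 1 to compound 4 (0.23 log units; within the scatter).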

Compound 4, half-maximal inhibitory concentration: 13.3 nM
Compound 4: middle estimate off by 3.0-fold (0.48 log units), on the high side; the measured number falls inside the stated range.
By their numbers in this assay, from the lowest: compounds 4 and 1 (each within the scatter of the next); then compound 3; then compound 2.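

In this assay, within the data shown here, this pair gives the first direct reading of a single change at this position: isopropyl in place of ethoxy on this aromatic carbon gives a 1.8-fold lower number from compound 1 to compound 4 (0.25 log units; within the scatter) and so leaves the two compounds within the usual scatter of each other. The earlier compounds shown here could not show this, as none of them formed a pair differing only in this spot. The pair also shows that the hydrogen-bond acceptor counted on the ethoxy can be lost here, with an all-carbon group in its place, without a step beyond the scatter, so inhibition at this level does not depend on that acceptor in this compound. Nothing measured here accounts for why the two groups read so alike.

Still open, from the compounds shown here alone, is how far this position accepts other kinds of group, such as an amine, a carboxylic acid or a longer chain like butoxy, since ethoxy and isopropyl are the only two compared directly here. Also open, going by these compounds, is whether isopropyl in place of ethoxy would give a similarly small step on a different core.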